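A few compounds are considered here, and "the series" means these few. Any claim that something is new, unique, unknown or untested is made for them only; others in the source may bear on it.

The measured compounds:

Compound 1, `CC(C)N(Cc1cccc(OCCCCCC(=O)O)c1)C(=O)c1ccc(-c2ccco2)cc1`, gives > 26000 nM in an ADME assay on HepG2 cells (Homo sapiens) for cytotoxicity, read by CellTiter-Glo and resazurin assay, with a stated time of 72 h; a lower number here means that less compound is needed, a higher number that more compound is needed for the effect; this is a limit of the assay.
Compound 2, `CC(C)N(Cc1cccc(OCCCCCC(=O)O)c1)C(=O)c1ccc(-c2cccc(Oc3ccccc3)c2)cc1`, gives > 18700 nM in this assay; this is a limit of the assay.
Compound 3, `CC(C)N(Cc1cccc(OCCCCCC(=O)O)c1)C(=O)c1ccc(-c2cccc(OCc3ccccc3)c2)cc1`, gives > 26000 nM in this assay; this is a limit of the assay.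

Compound 2 thus stands only at a limit, and the two further values are limits as well. Going by the values given here, of the three values, one sits at the limit of > 18700 nM in this assay, at which 1 of the 3 values shown sits, and two at the limit of > 26000 nM in this assay, at which 2 of the 3 values shown sit, so no compound has a number. Among the compounds with values here, the one step that changes the group on this oxygen, a step that the two limits leave unreadable from compound 2 to compound 3, benzyl in place of phenyl on an oxygen on an aromatic ring, has a size that cannot be read.

Compound 4, `CC(C)N(Cc1cccc(OCCCCCC(=O)O)c1)C(=O)c1ccc(-c2cccc(OC(F)(F)F)c2)cc1`, differs from compound 2 by trifluoromethyl in place of phenyl on an oxygen on an aromatic ring. Only the unreadable step that the two limits leave unreadable from compound 2 to compound 3 bears on this change, so no direction can be drawn from it. The step from compound 2 to compound 4 is expected to be a step that the limit leaves unreadable from compound 2 to compound 4, not readable beyond the scatter. Compound 4 is estimated to give about 30000 nM in this assay, between 15000 nM and 100000 nM, most likely again as a limit.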

Compound 4, half-maximal effective concentration: > 26000 nM
Compound 4: a limit, no number; the forecaster's own chance of this, stated with the estimate: 85%; the middle value does not contradict the limit.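

Compound 4 also stands only at a limit in this assay, so its steps from compound 1, compound 2 and compound 3 cannot be read. The compounds shown leave open whether changing the group on this oxygen alters the effective concentration at all; none of the four has a number.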